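Swapping the pyridine on the shared core: clearance notes

The compounds below may be only part of what the source reports. "The series", "measured", "known", "first", "only" and "open" are said of these compounds alone.

Measured in an ADME assay (liver) for metabolic stability, with Liver microsome (Homo sapiens) as the target, using microsomes and NADPH, with a stated time of 30 min, tested at 1 uM; on this read-out lower numbers stand for slow clearance and higher numbers for fast clearance:
- compound 1 `Cn1cc(-c2cc(C(O)(C(F)(F)F)C(F)(F)F)cnc2N2CCN(S(=O)(=O)c3ccc(N)nc3)CC2)cn1`: 19 mL.min-1.g-1
- compound 2 `Nc1ccc(S(=O)(=O)N2CCN(c3ncc(C(O)(C(F)(F)F)C(F)(F)F)cc3-c3cncc(F)c3)CC2)cn1`: 24 mL.min-1.g-1

Compound 2 stands within the scatter of compound 1, so the two numbers do not separate. Compound 3 `Cc1ccc(-c2cc(C(O)(C(F)(F)F)C(F)(F)F)cnc2N2CCN(S(=O)(=O)c3ccc(N)nc3)CC2)cn1` is the next case, with 6-methylpyridin-3-yl in place of 5-fluoropyridin-3-yl on an aromatic carbon. Going by the values given here, the only measured step at this place, 5-fluoropyridin-3-yl in place of 1-methyl-1H-pyrazol-4-yl, is a 1.3-fold higher number from compound 1 to compound 2 (0.10 log units; within the scatter), which lies within the scatter. No shift beyond the scatter is therefore expected in this assay, and the expected step is a 1.1-fold higher number from compound 2 to compound 3 (0.05 log units; within the scatter). Compound 3 is estimated at 27 mL.min-1.g-1, with an expected range of 13 mL.min-1.g-1 to 55 mL.min-1.g-1.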

Compound 3, intrinsic clearance in microsomes: 43 mL.min-1.g-1
The estimate for compound 3 lay 1.6-fold (0.20 log units) below the measured number, and the stated range covers the measured number.
By their numbers in this assay, from the lowest: compounds 1, 2 and 3 (each within the scatter of the next, the first and the last beyond it).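

In this assay, going by these compounds alone, this aromatic carbon now gives a first step beyond the scatter, though a modest one, for 6-methylpyridin-3-yl in place of 1-methyl-1H-pyrazol-4-yl (a 2.3-fold higher number from compound 1 to compound 3 (0.35 log units; beyond the scatter)). The change between the two pyridines, 6-methylpyridin-3-yl in place of 5-fluoropyridin-3-yl, stays within the scatter (a 1.8-fold higher number from compound 2 to compound 3 (0.25 log units; within the scatter)), so these two groups do not separate. Nothing available accounts for either step.

Open, from the compounds shown here alone, is how an amine or a carboxylic acid on this aromatic carbon would read out. Also open, going by these compounds, is whether an ethyl in place of the methyl on the pyridine would separate from compound 3.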